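A few compounds are considered here, and "the series" means these few. Any claim that something is new, unique, unknown or untested is made for them only; others in the source may bear on it.

Compound 3 `CN1[C@@H]2c3[nH]c4ccccc4c3C[C@H]1[C@H](C#N)N1[C@@H](CNC(=O)c3cc4ccccc4[nH]3)c3[nH]c4ccccc4c3C[C@@H]21` gives 9780 nM in a functional assay on MCF7 cells (Homo sapiens) for cytotoxicity, read by MTT assay, with a stated time of 72 h (on this read-out lower numbers stand for stronger inhibition and higher numbers for weaker inhibition), the highest of the three numbers measured. Compound 1 `CCc1ccc(C(=O)NC[C@H]2c3[nH]c4ccccc4c3C[C@H]3[C@H]4c5[nH]c6ccccc6c5C[C@@H]([C@H](C#N)N23)N4C)cc1` gives 170 nM, and compound 2 `CN1[C@@H]2c3[nH]c4ccccc4c3C[C@H]1[C@H](C#N)N1[C@@H](CNC(=O)c3ccc4ccccc4n3)c3[nH]c4ccccc4c3C[C@@H]21` gives 150 nM. Compound 4 `CN1[C@@H]2c3[nH]c4ccccc4c3C[C@H]1[C@H](C#N)N1[C@@H](CNC(=O)/C=C/c3ccccc3)c3[nH]c4ccccc4c3C[C@@H]21` differs from compound 3 by 2-phenylethenyl in place of 1H-indol-2-yl on a carbonyl carbon. For the measured compounds named here, the steps that bear on this change are a 58-fold higher number from compound 1 to compound 3 (1.76 log units; beyond the scatter) and a 65-fold higher number from compound 2 to compound 3 (1.81 log units; beyond the scatter), both large, whereas a 1.1-fold lower number from compound 1 to compound 2 (0.05 log units; within the scatter), so the two aryl amides sit close together. Given those two large rises on entering the indolyl group, a fall of comparable size on leaving it is expected for compound 4, as a 33-fold lower number from compound 3 to compound 4 (1.51 log units; beyond the scatter). Compound 4 is therefore estimated at about 300 nM in this assay, with a range from 100 nM to 1500 nM.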

Compound 4, half-maximal inhibitory concentration: 7190 nM
Estimate against measurement, compound 4: 24-fold (1.38 log units) below, and the stated range ends below it.
By their numbers in this assay, from the lowest: compounds 2 and 1 (each within the scatter of the next); then compounds 4 and 3 (each within the scatter of the next).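

In this assay, the change to 2-phenylethenyl on the carbonyl carbon leaves the number where it was, with a 1.4-fold lower number from compound 3 to compound 4 (0.13 log units; within the scatter), so the high number of compound 3 is not unique to 1H-indol-2-yl and occurs both with and without a hydrogen-bond donor in the group. Both groups stand apart from the other two, with a 48-fold higher number from compound 2 to compound 4 (1.68 log units; beyond the scatter) and a 42-fold higher number from compound 1 to compound 4 (1.63 log units; beyond the scatter). Nothing measured here explains this split. On these data alone, whether a saturated alkyl chain or an amine on this carbonyl carbon would join the lower pair or the higher pair remains open.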